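The source may report more compounds than this note shows. Statements on the series, on what has been measured and on what is new or still open speak of the compounds shown alone.

Compound 1 `Cn1cc(-c2cnc(NCc3c(F)ccc4c3CCO4)c3cn[nH]c(=O)c23)cn1`: 21 mL.min-1.g-1
Compound 2 `Cn1nccc1-c1cnc(NCc2c(F)ccc3c2CCO3)c2cn[nH]c(=O)c12`: 14 mL.min-1.g-1
Compound 3 `O=C1CCCN1c1cnc(NCc2c(F)ccc3c2CCO3)c2cn[nH]c(=O)c12`: 23 mL.min-1.g-1

These three compounds share one core and differ in a single group on an aromatic carbon. Their numbers come from an ADME assay on microsomes from liver (Homo sapiens) for metabolic stability, read by LC-MS, using NADPH, with stated times of 5 min and 30 min, tested at 1 uM; on this read-out lower numbers stand for slow clearance and higher numbers for fast clearance. Compound 3 is not truly separated from the other two, as the step to it from each of them lies within the scatter of repeated measurements (a 1.1-fold higher number from compound 1 to compound 3 (0.04 log units; within the scatter) and a 1.6-fold higher number from compound 2 to compound 3 (0.22 log units; within the scatter)).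

Compound 4 `CC(=O)N1CCC(c2cnc(NCc3c(F)ccc4c3CCO4)c3cn[nH]c(=O)c23)CC1` has not been measured yet. It carries 1-acetylpiperidin-4-yl in place of 2-oxopyrrolidin-1-yl on an aromatic carbon.

Among the measured compounds shown here, three measured steps bear on this change, since each swaps one group for another at this same carbon. Besides the two steps to compound 3, there is the swap between the two methylpyrazolyl groups (a 1.5-fold lower number from compound 1 to compound 2 (0.18 log units; within the scatter)). All three are small, and none moves the number beyond the scatter. However, none of them tests a group like 1-acetylpiperidin-4-yl, so the evidence is indirect and the range must stay wide.

In this assay the expected outcome is therefore no step beyond the scatter (estimated: a 1.0-fold lower number from compound 3 to compound 4 (0.02 log units; within the scatter)). For compound 4 the estimated value is 22 mL.min-1.g-1 with an expected range from 11 mL.min-1.g-1 to 42 mL.min-1.g-1 until the measurement is available.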

Compound 4, intrinsic clearance in microsomes: 207 mL.min-1.g-1
Compound 4: middle estimate off by 9.4-fold (0.97 log units), on the low side; measured number outside the range, above it.
By their numbers in this assay, from the lowest: compounds 2, 1 and 3 (each within the scatter of the next); then compound 4.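

In this assay this position turns out to be far less forgiving than the first three compounds suggested: swapping among the two methylpyrazolyl groups and 2-oxopyrrolidin-1-yl stayed within the scatter, yet 1-acetylpiperidin-4-yl moves the number well beyond it against each of them (a 9.0-fold higher number from compound 3 to compound 4 (0.95 log units; beyond the scatter)) and (a 9.9-fold higher number from compound 1 to compound 4 (0.99 log units; beyond the scatter)) and (a 15-fold higher number from compound 2 to compound 4 (1.17 log units; beyond the scatter)). The step from 2-oxopyrrolidin-1-yl swaps a five-membered non-aromatic ring for a larger six-membered one, while the counts of hydrogen-bond donors and acceptors stay the same and neither group has a net charge, so those counts alone do not separate a compound with slow clearance from one with fast clearance. Nothing measured here says what lies behind this jump in clearance.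

Still open, from the compounds shown here alone, is whether the jump belongs to the piperidine ring itself or to the acetyl group on it, as both enter together in compound 4. A piperidin-4-yl group with a free amine, or a 1-acetylpyrrolidin-3-yl group on the same aromatic carbon, would pull those two parts apart.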